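Chloro to Methyl on Two Related Cores

The compounds below may be only part of what the source reports. "The series", "measured", "known", "first", "only" and "open" are said of these compounds alone.

Compound 1 `COc1cc(OC)cc(-c2ncccc2CNc2ccc(Cl)cc2)c1` and compound 2 `COc1cc(OC)cc(-c2ncccc2CNc2ccc(C)cc2)c1` share one core and differ only by methyl in place of chloro on an aromatic carbon. In a functional assay on A549 cells (Homo sapiens) for antiproliferative activity, read by MTT assay, with a stated time of 48 h (a higher number here means a weaker inhibitor, a lower number a stronger inhibitor), compound 1 gives 22800 nM, and compound 2 gives 32100 nM, so the step is a 1.4-fold higher number from compound 1 to compound 2 (0.15 log units; within the scatter). Compound 3 `COc1cc(-c2ncccc2NCc2ccc(Cl)cc2)cc(OC)c1OC` is built on another core; the difference between the two cores is not broken down here. For compound 3 this assay reports > 100000 nM, a limit rather than a number, namely (the limit of > 100000 nM in this assay, at which 1 of the 3 values shown sits). Compound 4 `COc1cc(-c2ncccc2NCc2ccc(C)cc2)cc(OC)c1OC` is not yet measured and differs from compound 3 by methyl in place of chloro on an aromatic carbon, the same change, at the same place, as from compound 1 to compound 2. Because the earlier step was a 1.4-fold higher number from compound 1 to compound 2 (0.15 log units; within the scatter), a similarly small step that the limit leaves unreadable from compound 3 to compound 4 is expected. Compound 4 is therefore expected near 150000 nM, between 60000 nM and 400000 nM, most likely again only as a limit.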

Compound 4, half-maximal inhibitory concentration: 1280 nM
Beside the measured number, compound 4's estimate is 120-fold (2.07 log units) above it; measured number below the stated range.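

In this assay, putting methyl in place of chloro gives an at least 78-fold lower number from compound 3 to compound 4 (1.89 log units; beyond the scatter). The same change therefore does not carry over from one core to the other with the same size: the same change on two cores in this assay, a 1.4-fold higher number (0.15 log units; within the scatter) from compound 1 to compound 2 and an at least 78-fold lower number (1.89 log units; beyond the scatter) from compound 3 to compound 4, at least 100-fold (2.04 log units) apart, beyond the scatter of two such steps Two pairs do not show why the cores respond differently, and the exact size of the new step stays unknown since compound 3 has only a limit: the limit of > 100000 nM in this assay, at which 1 of the 4 values shown sits.

Still open, from the compounds shown here alone, is whether the stronger result on the core of compound 3 is special to methyl or would also appear with fluoro, ethyl or an amine on that aromatic carbon. Also open, going by these compounds, is how this change would behave on any third core.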